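Benzimidazole-substituent notes: methyl to trifluoromethyl at the two-position

A few compounds are considered here, and "the series" means these few. Any claim that something is new, unique, unknown or untested is made for them only; others in the source may bear on it.

Measured so far:
compound 1 `O=C(CCCN1CCC(n2cnc3ccccc32)CC1)c1ccc(F)cc1` gives 4.7 mg/kg
compound 2 `Cc1nc2ccccc2n1C1CCN(CCCC(=O)c2ccc(F)cc2)CC1` gives 0.85 mg/kg

Both numbers come from a functional assay on the whole organism (strain STD-ddY) for inhibition, with Mus musculus as the target, with a stated time of 5 min; a lower number here means that less compound is needed, a higher number that more compound is needed for the effect. Going by the values given here, compound 2 stands at the lower of the two values; the only measured step, a 5.5-fold lower number from compound 1 to compound 2 (0.74 log units; beyond the scatter), puts a methyl on the aromatic carbon of the five-membered ring and lowers the dose needed, a change beyond the scatter.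

Compound 3 `O=C(CCCN1CCC(n2c(C(F)(F)F)nc3ccccc32)CC1)c1ccc(F)cc1` carries the change (trifluoromethyl in place of methyl on an aromatic carbon). Among the compounds with values here, no measured pair exchanges methyl for trifluoromethyl, so the single known step bears on compound 3 only indirectly: it shows that a substituent at this aromatic carbon is tolerated and helpful relative to hydrogen. Whether a larger group there keeps that gain is not shown by any measured compound.

The expectation is therefore a dose close to compound 2, with the step of a 1.8-fold higher number from compound 2 to compound 3 (0.25 log units; within the scatter) estimated to stay within or near the scatter. For compound 3 the estimate in this assay is 1.5 mg/kg, with a range from 0.5 mg/kg to 5 mg/kg.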

Compound 3, dose for half-maximal effect: > 40 mg/kg
Compound 3: no number, only a limit; the forecaster's own chance of this, stated with the estimate: 5%; at least 26-fold (1.42 log units) between middle value and limit.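

Compound 3 yields a limit and not a number in this assay: the limit of > 40 mg/kg in this assay, at which 1 of the 3 values shown sits.

Exchanging methyl for trifluoromethyl gives an at least 47-fold higher number from compound 2 to compound 3 (1.67 log units; beyond the scatter), so this aromatic carbon between two ring nitrogen atoms does not accept every substituent, and the benefit seen with methyl is not a general result of substitution there. Measured against hydrogen, trifluoromethyl gives an at least 8.5-fold higher number from compound 1 to compound 3 (0.92 log units; beyond the scatter), which places it on the opposite side of the unsubstituted compound from methyl, so the direction of the change at this carbon depends on the group.

From the compounds shown here alone, whether an ethyl group, a chlorine atom or an amine at this place would side with methyl or with trifluoromethyl remains open. The three compounds also give no cause for the loss.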